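The source may hold more compounds than are shown below. What is called first, only, known or untested is meant among the compounds shown, and "the series" means these compounds.

Three compounds share one core and differ only in the aromatic group carried on the nitrogen of the five-membered ring. Compound 1 `CC1(C)[C@H]2CC[C@]1(C)N(Cc1cn(-c3ccccc3C#N)nn1)C(=O)C2` carries a 2-cyanophenyl group, compound 2 `CC1(C)[C@H]2CC[C@]1(C)N(Cc1cn(-c3ccc(F)cc3)nn1)C(=O)C2` a 4-fluorophenyl group and compound 3 `Cc1ccc(-n2cc(CN3C(=O)C[C@@H]4CC[C@@]3(C)C4(C)C)nn2)cc1` a 4-methylphenyl group. In a functional assay on A549 cells (Homo sapiens) for inhibition, read by MTT assay, with a stated time of 24 h (a higher number here means a weaker inhibitor, a lower number a stronger inhibitor), compound 1 gives 100 nM, compound 2 gives 230 nM and compound 3 gives 400 nM. Compound 2 therefore stands with the second highest number of the three: the step of a 1.7-fold higher number from compound 2 to compound 3 (0.24 log units; within the scatter) lies within the scatter, while the step of a 2.3-fold higher number from compound 1 to compound 2 (0.36 log units; beyond the scatter) lies beyond it.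

Compound 4 `CC1(C)[C@H]2CC[C@]1(C)N(Cc1cn(-c3cccc(Br)c3)nn1)C(=O)C2` is the next case: 3-bromophenyl in place of 4-fluorophenyl on an aromatic nitrogen. For the measured compounds named here, the steps that bear on this are the earlier swaps of the aromatic group, namely a 2.3-fold higher number from compound 1 to compound 2 (0.36 log units; beyond the scatter), a 4.0-fold higher number from compound 1 to compound 3 (0.60 log units; beyond the scatter) and a 1.7-fold higher number from compound 2 to compound 3 (0.24 log units; within the scatter), all modest or within the scatter. None of them involves a bromine or a group at this position, so there is no direct guide. Only a small step is expected, most likely none beyond the scatter, with a slight lean towards a higher number because a 2.3-fold higher number from compound 1 to compound 2 (0.36 log units; beyond the scatter) and a 4.0-fold higher number from compound 1 to compound 3 (0.60 log units; beyond the scatter) both raised the number.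

For compound 4 in this assay the estimate is 300 nM, with a range from 120 nM to 750 nM. This estimate corresponds to the expected step of a 1.3-fold higher number from compound 2 to compound 4 (0.12 log units; within the scatter).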

Compound 4, half-maximal inhibitory concentration: 90 nM
For compound 4 the middle estimate is 3.3-fold (0.52 log units) above the measured one; the whole stated range lies above it.
By their numbers in this assay, from the lowest: compounds 4 and 1 (each within the scatter of the next); then compounds 2 and 3 (each within the scatter of the next).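

In this assay, this position proves able to carry a group other than 2-cyanophenyl and still give a low number: the change to 3-bromophenyl lowers the number beyond the scatter, both against 4-fluorophenyl (a 2.6-fold lower number from compound 2 to compound 4 (0.41 log units; beyond the scatter)) and against 4-methylphenyl (a 4.4-fold lower number from compound 3 to compound 4 (0.65 log units; beyond the scatter)). Set against 2-cyanophenyl, the same group gives no change beyond the scatter (a 1.1-fold lower number from compound 1 to compound 4 (0.05 log units; within the scatter)), so two quite different aromatic groups sit at the same level, and the low number of compound 1 is not unique to its nitrile. The 4-fluorophenyl and 3-bromophenyl groups match in heavy atoms, hydrogen-bond donors and acceptors, so those counts do not separate them, and no measurement here explains the gap between them.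

Bromine replaces fluorine and the substituent also changes place in this one step, so it remains open which of the two matters; 4-bromophenyl and 3-fluorophenyl would separate them. As far as these compounds go, it is also open how the number responds when the aromatic ring carries an amine or a carboxylic acid, or when a longer chain replaces the ring altogether.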